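Swapping Thiophen-2-yl for Cyclopentyl on the Shared Core

The compounds below may be only part of what the source reports. "The series", "measured", "known", "first", "only" and "open" are said of these compounds alone.

In a functional assay on MCF7 cells (Homo sapiens) for cytotoxicity, read by WST assay, with a stated time of 72 h (on this read-out lower numbers stand for stronger inhibition and higher numbers for weaker inhibition), compound 1 `O=C1Nc2c(ccc(F)c2F)C1(c1ccc(O)cc1)c1ccc(F)c(F)c1` gives 7.8 nM, while compound 2 `O=C1Nc2c(ccc(F)c2F)C1(c1ccc(O)cc1)c1cccs1` gives 82 nM. Among the compounds with values here, compound 2 therefore holds the higher of the two numbers measured so far and is the weaker inhibitor of the pair. Within the data shown here, the single measured step, an 11-fold higher number from compound 1 to compound 2 (1.02 log units; beyond the scatter), is large and lies beyond the scatter. It places thiophen-2-yl where 3,4-difluorophenyl stood on a saturated ring carbon.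

Compound 3 `O=C1Nc2c(ccc(F)c2F)C1(c1ccc(O)cc1)C1CCCC1` changes that same carbon again, with cyclopentyl in place of thiophen-2-yl on a saturated ring carbon. The entering ring is five-membered like the one it replaces, but it is non-aromatic and of carbon only. Among the measured compounds shown here, no measured pair shows such an exchange, so the evidence is indirect. For the measured compounds named here, in compound 2, the step of an 11-fold higher number from compound 1 to compound 2 (1.02 log units; beyond the scatter) shows only that the number can move strongly with the group on this carbon.

A further rise in the number, smaller than that one, is expected, and the estimated step is a 2.4-fold higher number from compound 2 to compound 3 (0.39 log units; beyond the scatter). For compound 3 the expected value is 200 nM, with an estimated range of 50 nM to 900 nM.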

Compound 3, half-maximal inhibitory concentration: 12 nM
Beside the measured number, compound 3's estimate is 17-fold (1.22 log units) above it; measured number outside the range, below it.
By their numbers in this assay, from the lowest: compounds 1 and 3 (each within the scatter of the next); then compound 2.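

In this assay, the step of a 6.8-fold lower number from compound 2 to compound 3 (0.83 log units; beyond the scatter) shows that the weaker result of thiophen-2-yl does not extend to every five-membered ring on this saturated ring carbon, as cyclopentyl has the same number of heavy atoms yet gives a much lower number. The step of a 1.5-fold higher number from compound 1 to compound 3 (0.19 log units; within the scatter) lies within the scatter, so cyclopentyl and 3,4-difluorophenyl cannot be told apart here, and an aromatic ring on this carbon is therefore not needed for a number like that of compound 1. Nothing available here accounts for the gap between thiophen-2-yl and the other two groups.

The compounds shown leave open how far this tolerance for a non-aromatic ring of carbon only extends, for instance to cyclopropyl, cyclohexyl or an open chain such as isopropyl. They also leave open whether the high number of compound 2 belongs to the sulfur-containing ring as a whole or to how it is attached, which thiophen-3-yl could test, and whether a piperidine ring carrying an amine would be accepted on the same carbon.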